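Formyl in place of ethynyl on the distal ring

A few compounds are considered here, and "the series" means these few. Any claim that something is new, unique, unknown or untested is made for them only; others in the source may bear on it.

Measured compounds in an in vitro functional assay on 1321-N1 cells for agonist activity at Free fatty acid receptor 1 (Homo sapiens), read by fluorescence; a higher number here means that more compound is needed for the effect, a lower number that less compound is needed:
compound 1 `O=C(O)CCc1ccc(C#Cc2ccccc2)cc1`, 95.5 nM; 96 nM (2 entries)
compound 2 `C#Cc1cccc(C#Cc2ccc(CCC(=O)O)cc2)c1`, 155 nM

Compound 2 has one single number in this assay, 155 nM, plus a further entry that gave no single number. Compound 1 is the only other point, with repeated entries close together (the several entries of compound 1 in this assay, 95.5 nM; 96 nM (2 entries)). Compound 3 `O=Cc1cccc(C#Cc2ccc(CCC(=O)O)cc2)c1` differs from compound 2 in one place: formyl in place of ethynyl on an aromatic carbon, a formyl in place of ethynyl on an aromatic carbon, meta to a large group. Among the compounds with values here, no measured pair shows such a swap, so compound 3 is expected near compound 2, with a step of a 1.4-fold higher number from compound 2 to compound 3 (0.15 log units; within the scatter) that may not exceed the scatter. Compound 3 is estimated at 220 nM, within 80 nM to 650 nM.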

Compound 3, half-maximal effective concentration: 355 nM
Compound 3: the middle estimate sits 1.6-fold (0.21 log units) below what was measured; the measured number falls inside the stated range.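

Putting formyl in place of ethynyl on this aromatic carbon gives, in this assay, a 2.3-fold higher number from compound 2 to compound 3 (0.36 log units; beyond the scatter), so two groups with the same count of heavy atoms are not interchangeable here. The step is modest, but repeated entries in this assay can agree closely: the several entries of compound 1 in this assay, 95.5 nM; 96 nM (2 entries). The swap changes both the multiple bond and the hydrogen-bond acceptor count, and these compounds cannot separate the two. From the compounds shown here alone, whether a nitrile or a hydroxymethyl group on this carbon would sit closer to compound 2 or to compound 3 remains open.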